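Aminoimidazopyrazine series: anilide variation and cell growth inhibition

The compounds below may be only part of what the source reports. "The series", "measured", "known", "first", "only" and "open" are said of these compounds alone.

Working notes on a small set built around a shared core carrying an N-methylpiperazine and a methylindazole. Compound 1 `Cc1n[nH]c2ccc(-c3nc4cnc(N5CCN(C)CC5)cn4c3Nc3cccc(F)c3)cc12` and compound 3 `Cc1ccc(C)c(Nc2c(-c3ccc4[nH]nc(C)c4c3)nc3cnc(N4CCN(C)CC4)cn23)c1` belong to the set, but for compound 1 the result in a functional assay on CWR22R cells (Homo sapiens) for inhibition, with a stated time of 120 h (a higher number here means a weaker inhibitor, a lower number a stronger inhibitor), stands as "not determined" (no result reported), and for compound 3 the entry in this assay is "not determined" (no result reported). Going by the values given here, compound 2 `Cc1n[nH]c2ccc(-c3nc4cnc(N5CCN(C)CC5)cn4c3Nc3ccc(F)cc3)cc12` is therefore the only member with a number: in this assay compound 2 gives 33600 nM, a weak result, and it is the single point of reference, with no step between two measured compounds available for calibration.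

Compound 4 `Cc1n[nH]c2ccc(-c3nc4cnc(N5CCN(C)CC5)cn4c3Nc3ccc(Cl)cc3F)cc12` is not yet measured. It differs from compound 2 in one place: 4-chloro-2-fluorophenyl in place of 4-fluorophenyl on a nitrogen on an aromatic ring. Among the compounds with values here, with no measured step to lean on, the size of the change from compound 2 to compound 4 in this assay cannot be anchored; the expectation is a modest shift, if any, within or near the usual scatter, and slightly toward stronger inhibition rather than weaker. The expected step is a 1.7-fold lower number from compound 2 to compound 4 (0.23 log units; within the scatter). For compound 4 the estimate in this assay is 20000 nM, with a range from 5000 nM to 80000 nM.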

Compound 4, half-maximal inhibitory concentration: 14100 nM
Compound 4: middle estimate off by 1.4-fold (0.15 log units), on the high side; the range from low to high includes it.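

The series now has its first readable step at this position: in this assay, 4-chloro-2-fluorophenyl in place of 4-fluorophenyl on a nitrogen on an aromatic ring gives a 2.4-fold lower number from compound 2 to compound 4 (0.38 log units; beyond the scatter), so the number does respond to a change in this group, though only modestly. Compound 4, at 14100 nM, still sits in the weak range set by compound 2, so this change does not lift the series out of that range. Nothing measured here bears on why the number moved.

Steps to compound 1 and compound 3 cannot be read, so the effect of moving the fluorine or of adding methyl groups on the same ring remains unknown. Since compound 4 differs from compound 2 by one swap of the whole group, the shares of the chlorine and the second fluorine cannot be separated, and 4-chlorophenyl alone, or a phenyl carrying an amine or a carboxylic acid, would show whether this position tolerates anything beyond halogens.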